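A few compounds are considered here, and "the series" means these few. Any claim that something is new, unique, unknown or untested is made for them only; others in the source may bear on it.

Measured so far:
- compound 1, `CCOC(=O)C1=C(Nc2ccccc2)S/C(=C\c2ccccc2)C1=O`: 42.9%
- compound 2, `CCOC(=O)C1=C(Nc2ccccc2)S/C(=C\c2ccc(C(=O)O)cc2)C1=O`: 27.5%

In a functional assay on K562 cells (Homo sapiens) for inhibition, read by MTT assay, with a stated time of 72 h, tested at 10 uM (on this read-out higher numbers stand for more inhibition at the one concentration tested (going by the name of the read-out) and lower numbers for less inhibition), compound 1 gives 42.9%. In this assay compound 2 gives 27.5%. Within the data shown here, the one measured step is a number 15.4 percentage points lower from compound 1 to compound 2 (beyond the scatter), so compound 2 stands lowest of the two numbers, with compound 1 as its only neighbour.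

Compound 3, `CCOC(=O)C1=C(Nc2ccccc2)S/C(=C\c2ccc[nH]2)C1=O`, is the next compound to be measured in this assay. It differs from compound 2 by 1H-pyrrol-2-yl in place of 4-carboxyphenyl on a double-bonded chain carbon bound to a double-bonded ring carbon. The measured step bears on this change only in part: it shows what the carboxy group did when it entered, and that group now leaves again, but nothing measured shows what a 1H-pyrrol-2-yl does when it replaces the whole 4-carboxyphenyl.

Among the measured compounds shown here, since the only change with a known effect is undone, compound 3 is expected to move back toward compound 1, with a step of about a number 12.5 percentage points higher from compound 2 to compound 3 (beyond the scatter) in this assay expected, upward, though the new ring leaves this uncertain. For compound 3 the estimated value in this assay is 40%, within a range from 20% to 60%.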

Compound 3, a percentage reported as inhibition, at one concentration (the size of the read-out at that concentration, not a potency): 16.2%
For compound 3 the middle estimate is 23.8 percentage points above the measured one; measured number outside the range, below it.
By their numbers in this assay, from the lowest: compound 3; then compound 2; then compound 1.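

In this assay, 1H-pyrrol-2-yl in place of 4-carboxyphenyl gives a number 11.3 percentage points lower from compound 2 to compound 3 (beyond the scatter) and, in place of phenyl, a number 26.7 percentage points lower from compound 1 to compound 3 (beyond the scatter) on the same double-bonded chain carbon. The earlier compounds shown here showed only what a carboxy group on the phenyl ring did; these steps show that the whole ring at this place can be changed with a result beyond the scatter, and that losing the carboxy group does not by itself bring the number back up. Among the three compounds, the one with the five-membered aromatic ring stands lowest, under both compounds with a six-membered aromatic ring, and no measurement on hand gives a reason for this.

The compounds shown leave open whether the lower number goes with the smaller ring, with its ring nitrogen and that nitrogen's hydrogen, or with both. From the compounds shown here alone, what a furan-2-yl or a thiophen-2-yl would give at this place stays unknown, as does the effect of an amine or a methoxy group on the phenyl ring, and every comparison here rests on the one concentration tested.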